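Working notes: from compound 3 to compound 4

A few compounds are considered here, and "the series" means these few. Any claim that something is new, unique, unknown or untested is made for them only; others in the source may bear on it.

Of the compounds shown here, three on the shared core have been read so far in a functional assay on HL-60 cells (Homo sapiens) for antiproliferative activity, with a stated time of 72 h (on this read-out lower numbers stand for stronger inhibition and higher numbers for weaker inhibition), and they frame the step. Compound 1 (`OC[C@H]1O[C@@H](n2cnc3c(NCc4ccccc4F)ncnc32)[C@H](O)[C@@H]1O`) gives 3200 nM on this read-out. Compound 2 (`Cc1cccc(CNc2ncnc3c2ncn3[C@@H]2O[C@H](CO)[C@@H](O)[C@H]2O)c1`) gives 6400 nM on the same read-out. The pair shows a 2.0-fold higher number from compound 1 to compound 2 (0.30 log units; within the scatter) and so no real separation.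

Compound 3 (`Cc1ccc(CNc2ncnc3c2ncn3[C@@H]2O[C@H](CO)[C@@H](O)[C@H]2O)cc1`) gives no number, only the limit > 166000 nM and thus sits at the limit of > 166000 nM in this assay, at which 1 of the 3 values shown sits, on the scale. Two large steps end there: an at least 51-fold higher number from compound 1 to compound 3 (1.71 log units; beyond the scatter) and an at least 25-fold higher number from compound 2 to compound 3 (1.41 log units; beyond the scatter) both stand beyond the scatter.

Compound 4 (`COc1cccc(CNc2ncnc3c2ncn3[C@@H]2O[C@H](CO)[C@@H](O)[C@H]2O)c1`) differs by 3-methoxyphenyl in place of 4-methylphenyl on a saturated chain carbon bound to a nitrogen on an aromatic ring in one place: 3-methoxyphenyl in place of 4-methylphenyl on a saturated chain carbon bound to a nitrogen on an aromatic ring. The expectation leans on compound 2 at 6400 nM with its 3-methylphenyl, the group name closest to the entering 3-methoxyphenyl. For the measured compounds named here, no measured compound carries a methoxy group, so that oxygen remains untested.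

A large step toward stronger inhibition is expected in this assay and is estimated as an at least 20-fold lower number from compound 3 to compound 4 (1.31 log units; beyond the scatter) from the limit onward. Compound 4 is estimated at 8000 nM with an expected range from 2500 nM to 30000 nM on this reasoning.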

Compound 4, half-maximal inhibitory concentration: 4900 nM
The estimate for compound 4 lay 1.6-fold (0.21 log units) above the measured number, and the stated range covers the measured number.
By their numbers in this assay, from the lowest: compounds 1, 4 and 2 (each within the scatter of the next). At a limit, above all of these: compound 3.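

In this assay, methoxy in place of methyl on an aromatic carbon brings no separation: a 1.3-fold lower number from compound 2 to compound 4 (0.12 log units; within the scatter), and a 1.5-fold higher number from compound 1 to compound 4 (0.19 log units; within the scatter), so 3-methoxyphenyl, 3-methylphenyl and 2-fluorophenyl on the saturated chain carbon bound to a nitrogen on an aromatic ring all read alike within the scatter. The one compound shown that goes against this is the 4-methylphenyl member, and the new large step, an at least 33-fold lower number from compound 3 to compound 4 (1.52 log units; beyond the scatter), shows that adding an oxygen to the group does not cost the activity that 4-methylphenyl lacks, so the outlier remains that single group. Compound 3 still gives a limit and not a number, which leaves the true size of all its steps unfixed: the limit of > 166000 nM in this assay, at which 1 of the 4 values shown sits.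

From the compounds shown here alone, whether the gap belongs to the 4-methylphenyl group alone or extends to other groups of that naming, such as 4-methoxyphenyl or 4-fluorophenyl, stays open. Also open, going by these compounds, is how the read-out responds to an amine or a carboxylic acid on the phenyl ring, or to a longer chain between the ring and the nitrogen.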